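Swapping the Carboxyphenyl End on a Cyclopentyl Core

This account rests on a few compounds, and the source may have more. Where it says the series, first, only, none or still open, it means among the compounds named here.

Compound 1 `Cc1cc(OCCCCOc2ccc(C(=O)CC(C)C)c(O)c2C)ccc1C(=O)O` gives 173 nM in an assay on HEK293 cells for positive allosteric modulation of metabotropic glutamate receptor 2 (Rattus norvegicus), read by thallium flux, with a stated time of 2.5 min; a lower number here means that less compound is needed, a higher number that more compound is needed for the effect. Compound 2 `Cc1c(OCCCCOc2ccc(F)c(C(=O)O)c2)ccc(C(=O)CC(C)C)c1O` differs from it by 3-carboxy-4-fluorophenyl in place of 4-carboxy-3-methylphenyl on an oxygen on a saturated carbon, and in this assay compound 2 gives 153 nM, so that a 1.1-fold lower number from compound 1 to compound 2 (0.05 log units; within the scatter). Compound 3 `Cc1cc(OCCCCOc2ccc(C(=O)CC3CCCC3)c(O)c2C)ccc1C(=O)O` carries a different core, which differs from the core of compound 1 by cyclopentyl in place of isopropyl on a saturated chain carbon bound to a carbonyl carbon; in this assay compound 3 gives 564 nM, and a 3.3-fold higher number from compound 1 to compound 3 (0.51 log units; beyond the scatter). Compound 4 `Cc1c(OCCCCOc2ccc(F)c(C(=O)O)c2)ccc(C(=O)CC2CCCC2)c1O` has not yet been measured. It differs from compound 3 by 3-carboxy-4-fluorophenyl in place of 4-carboxy-3-methylphenyl on an oxygen on a saturated carbon, which is the same change that turned compound 1 into compound 2, made at a place that is described in the same words on both cores. Because that change gave a 1.1-fold lower number from compound 1 to compound 2 (0.05 log units; within the scatter), the step on the cyclopentyl-bearing core is expected to be about as small, namely a 1.1-fold lower number from compound 3 to compound 4 (0.04 log units; within the scatter). Compound 4 is therefore estimated to give 510 nM, with an expected range from 250 nM to 1100 nM.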

Compound 4, half-maximal effective concentration: 699 nM
For compound 4 the middle estimate is 1.4-fold (0.14 log units) below the measured one; the range from low to high includes it.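

On the cyclopentyl-bearing core, 3-carboxy-4-fluorophenyl in place of 4-carboxy-3-methylphenyl gives a 1.2-fold higher number from compound 3 to compound 4 (0.09 log units; within the scatter) in this assay, so this swap changes little here, and it behaves the same way on both cores: the same change on two cores in this assay, a 1.1-fold lower number (0.05 log units; within the scatter) from compound 1 to compound 2 and a 1.2-fold higher number (0.09 log units; within the scatter) from compound 3 to compound 4, 1.4-fold (0.15 log units) apart, within the scatter of two such steps

The other change in the set also carries over, with cyclopentyl in place of isopropyl giving a 4.6-fold higher number from compound 2 to compound 4 (0.66 log units; beyond the scatter), a step beyond the scatter that matches its earlier counterpart: the same change on two cores in this assay, a 3.3-fold higher number (0.51 log units; beyond the scatter) from compound 1 to compound 3 and a 4.6-fold higher number (0.66 log units; beyond the scatter) from compound 2 to compound 4, 1.4-fold (0.15 log units) apart, within the scatter of two such steps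

Together the four compounds form a closed square in which each change keeps its size on either core, but this rests on one pair per comparison in a single assay, so it shows neither why the steps agree nor that they would agree on any other core.

The compounds shown leave open whether this agreement would hold with a cyclohexyl group in place of cyclopentyl. They also leave open whether it would hold with a tetrazole or an amide in place of the carboxylic acid.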